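Spiro core series: amide substituent swap on compound 1

The compounds below may be only part of what the source reports. "The series", "measured", "known", "first", "only" and "open" are said of these compounds alone.

Going by the values given here, compound 1 `CC(C)(C)c1ccc(C(=O)N2CCC3(CC2)C(=O)N(CC(=O)NCN)CN3c2ccccc2)cc1` is the weakest of the three measured members: in an assay on HEK293 cells for displacement of a labelled ligand from NPC1-like intracellular cholesterol transporter 1 (Homo sapiens) (a lower number here means a stronger inhibitor, a higher number a weaker inhibitor), compound 1 gives 26500 nM, the highest of the three numbers. Compound 2 `O=C(CN1CN(c2ccccc2)C2(CCN(C(=O)c3ccc(C4CCCCC4)cc3)CC2)C1=O)NCCO` gives 2000 nM and compound 3 `CS(=O)(=O)NCCNC(=O)CN1CN(c2ccccc2)C2(CCN(C(=O)c3ccc(C4CCCCC4)cc3)CC2)C1=O` gives 2100 nM, both beyond the scatter from compound 1. Compound 1 differs from compound 2 and compound 3 in two places at once, so the gap cannot be assigned to either place from these data.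

Compound 4 `CCOC(=O)C1CCCN(C(=O)CN2CN(c3ccccc3)C3(CCN(C(=O)c4ccc(C(C)(C)C)cc4)CC3)C2=O)C1` is yet to be measured. It differs from compound 1 by 3-(ethoxycarbonyl)piperidin-1-yl in place of (aminomethyl)amino on a carbonyl carbon.

Among the compounds with values here, only one measured step exists, a 1.1-fold higher number from compound 2 to compound 3 (0.02 log units; within the scatter), and it changes a substituent on the same amide-type nitrogen without effect. It shows that this region tolerates a change from hydroxy to methanesulfonamido, but it does not cover the replacement of (aminomethyl)amino by a ring. Compound 1 has two distinguishing features, and the data do not tell which of them goes with its high value. Given that tolerance, a modest move toward the values of compound 2 and compound 3 is expected, with wide uncertainty. The expected step is a 3.3-fold lower number from compound 1 to compound 4 (0.52 log units; beyond the scatter). Compound 4 is therefore estimated at 8000 nM, within 2000 nM to 30000 nM.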

Compound 4, half-maximal inhibitory concentration: 8200 nM
The estimate for compound 4 lay 1.0-fold (0.01 log units) below the measured number, within the range that was stated.
By their numbers in this assay, from the lowest: compounds 2 and 3 (each within the scatter of the next); then compound 4; then compound 1.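

With the rest of compound 1 held fixed, the swap on the carbonyl carbon gives a 3.2-fold lower number from compound 1 to compound 4 (0.51 log units; beyond the scatter) in this assay, a modest change, so part of the high number of compound 1 goes with its (aminomethyl)amino group at this place. The place accepts 3-(ethoxycarbonyl)piperidin-1-yl, with 11 heavy atoms and one six-membered non-aromatic ring, in place of a group with 3 heavy atoms and no ring, and the number does not rise; the 2 hydrogen-bond donors of the leaving group are not needed to reach the value of compound 4. No measurement in hand gives a reason for this step.

Going by these compounds, the ring and the ethoxycarbonyl group enter together, so their shares stay open; a plain piperidin-1-yl group, or a carboxylic acid in place of the ethoxycarbonyl group, on the same carbonyl carbon would separate them. On these data alone, the other place in which compound 1 differs from compound 2 and compound 3 is not touched by this step, and its share of that gap also stays open.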